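A few compounds are considered here, and "the series" means these few. Any claim that something is new, unique, unknown or untested is made for them only; others in the source may bear on it.

Measured compounds: compound 1 `COc1cc(Nc2nc3ccccc3nc2S(=O)(=O)c2ccccc2)cc(OC)c1` gives 140 nM in a functional assay on PC-3 cells (Homo sapiens) for cytotoxicity, read by MTT assay, with a stated time of 72 h; on this read-out higher numbers stand for weaker inhibition and lower numbers for stronger inhibition; compound 2 `COc1cc(Nc2nc3ccccc3nc2S(=O)(=O)c2ccc(C)cc2)cc(OC)c1` gives 2940 nM; compound 3 `O=S(=O)(c1ccc(Br)cc1)c1nc2ccccc2nc1Nc1ccccc1` gives 1180 nM.

Compound 3 stands second highest of the three numbers, with compound 2 nearest and compound 1 furthest from it. The unmeasured compound 4 `COc1cc(Nc2nc3ccccc3nc2S(=O)(=O)c2ccc(Br)cc2)cc(OC)c1` arises from compound 3 by the change (3,5-dimethoxyphenyl in place of phenyl on a nitrogen on an aromatic ring). For the measured compounds named here, no measured step covers this change directly. Going by the values given here, the only measured step, a 21-fold higher number from compound 1 to compound 2 (1.32 log units; beyond the scatter), concerns a substituent on the sulfonyl-bearing ring, not the ring on the nitrogen, and so bears on the step to compound 4 only indirectly: it shows that compound 1, which already carries the 3,5-dimethoxyphenyl group, reaches the lowest number of the three when the sulfonyl-bearing ring is unsubstituted, whereas compound 3, carrying bromine on that ring and a plain phenyl on the nitrogen, sits far higher. Because compound 1 gives 140 nM, the dimethoxy group seems compatible with low numbers, so a modest decrease in this assay is expected, about a 2.0-fold lower number from compound 3 to compound 4 (0.29 log units; within the scatter). Compound 4 is therefore estimated at 600 nM, within 150 nM to 2500 nM.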

Compound 4, half-maximal inhibitory concentration: 18200 nM
Compound 4: the middle estimate sits 30-fold (1.48 log units) below what was measured; the measured number lies above the stated range.
By their numbers in this assay, from the lowest: compound 1; then compound 3; then compound 2; then compound 4.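

In this assay, for the compounds shown here, with bromine on the sulfonyl-bearing ring, 3,5-dimethoxyphenyl in place of phenyl on the nitrogen gives a 15-fold higher number from compound 3 to compound 4 (1.19 log units; beyond the scatter), the first measured step at this place, and it runs towards weaker inhibition. With the 3,5-dimethoxyphenyl group held fixed, bromo in place of hydrogen gives a 130-fold higher number from compound 1 to compound 4 (2.11 log units; beyond the scatter) and bromo in place of methyl gives a 6.2-fold higher number from compound 2 to compound 4 (0.79 log units; beyond the scatter), so the substituent on the other ring also moves the number strongly. The low number of compound 1 at 140 nM therefore does not carry over to the bromo compound, and the 3,5-dimethoxyphenyl group occurs here with both low and high numbers.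

On these data alone, whether phenyl and 3,5-dimethoxyphenyl differ the same way with hydrogen or methyl on the sulfonyl-bearing ring stays open, as does what a single methoxy group or an amine on the ring on the nitrogen would give. Nothing available explains the size of these steps.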